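The compounds below may be only part of what the source reports. "The series", "measured", "known", "first", "only" and "open" are said of these compounds alone.

Measured so far:
compound 1 `Cc1[nH]cnc1/C=c1\[nH]c(=O)/c(=C/c2cccc(C(=O)c3ccc(F)cc3)c2)[nH]c1=O` — 15.9 nM
compound 2 `O=c1[nH]/c(=C\C2CCCCC2)c(=O)[nH]/c1=C\c1cccc(Oc2ccc(F)cc2)c1` — > 1000 nM

In a functional assay on NCI-H460 cells (Homo sapiens) for cytotoxicity, read by MTT assay, with a stated time of 72 h (a lower number here means a stronger inhibitor, a higher number a weaker inhibitor), compound 1 gives 15.9 nM. For compound 2 the value of > 1000 nM in this assay is a limit of the assay and not a number, as the limit of > 1000 nM in this assay, at which 1 of the 2 values shown sits, shows. Within the data shown here, compound 2 thus stands at the limit, and no step between measured compounds differing in one place is available. Among the measured compounds shown here, compounds 1 and 2 differ in more than one place, so their two values show only that compound 1 carries the numerical value and compound 2 the limit.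

Compound 3 `O=c1[nH]/c(=C\c2cc3ccccc3o2)c(=O)[nH]/c1=C\c1cccc(Oc2ccc(F)cc2)c1` is not yet measured. It differs from compound 2 by 1-benzofuran-2-yl in place of cyclohexyl on a double-bonded chain carbon bound to an aromatic carbon. For the measured compounds named here, with no measured step to lean on, the change is expected to move in the direction of stronger inhibition by an at least 3.3-fold lower number from compound 2 to compound 3 (0.52 log units; beyond the scatter), beyond the usual scatter but uncertain. Compound 3 is expected to give about 300 nM in this assay, within a range from 50 nM to 3000 nM.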

Compound 3, half-maximal inhibitory concentration: 347 nM
Compound 3: the middle estimate sits 1.2-fold (0.06 log units) below what was measured, within the range that was stated.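

In this assay, 1-benzofuran-2-yl in place of cyclohexyl on a double-bonded chain carbon bound to an aromatic carbon gives an at least 2.8-fold lower number from compound 2 to compound 3 (0.45 log units; beyond the scatter). Compound 2 stands at a limit of the assay and not a number, so this step gives only a lower bound on the size of the change: the limit of > 1000 nM in this assay, at which 1 of the 3 values shown sits.

With the rest of the molecule held fixed, this position is thus shown to affect the read-out, which compounds 1 and 2, differing in more than one place, could not show.

Among these compounds, the single change alters the ring type, the ring count and the ring oxygen together, and a furan-2-yl or naphthalen-2-yl group at this place would be needed to tell these apart. As far as these compounds go, how compound 3 relates to compound 1 also stays open, as the two differ in more than one place.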